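Trifluoromethyl for propanoyl on the shared core

A few compounds are considered here, and "the series" means these few. Any claim that something is new, unique, unknown or untested is made for them only; others in the source may bear on it.

Compound 1 `CCC(=O)c1ccc2c(c1)C(n1ccccc1=O)=CC(C)(C)O2` is the most potent of the three compounds measured in a functional assay (trachea) with Rattus norvegicus as the target (on this read-out lower numbers stand for lower potency and higher numbers for higher potency (the scale is a negative logarithm)), where compound 1 gives 5.85. Among the measured compounds shown here, compound 2 `CC1(C)C=C(n2ccccc2=O)c2cc(OCC(=O)c3ccccc3)ccc2O1` gives 4.69 and compound 3 `CC1(C)C=C(n2ccccc2=O)c2cc(OC(=O)Nc3ccc(F)cc3)ccc2O1` gives 4.37; the one recorded step, a number 0.32 log units lower from compound 2 to compound 3 (beyond the scatter), concerns a group on an oxygen and does not touch the position changed here. Compound 4 `CC1(C)C=C(n2ccccc2=O)c2cc(C(F)(F)F)ccc2O1` differs from compound 1 by trifluoromethyl in place of propanoyl on an aromatic carbon. For the measured compounds named here, no measured step bears directly on this exchange; the only guidance is that compounds 2 and 3 with other groups on the same core sit well under compound 1. A moderate loss is therefore expected, estimated as a number 0.65 log units lower from compound 1 to compound 4 (beyond the scatter). Compound 4 is expected to give 5.2, between 4.5 and 5.9.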

Compound 4, logarithm of the reciprocal of the active concentration, log(1/C): 7.37
Beside the measured number, compound 4's estimate is 2.17 log units below it, outside the stated range (above it).
By their numbers in this assay, from the lowest: compound 3; then compound 2; then compound 1; then compound 4.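

In this assay, trifluoromethyl in place of propanoyl gives a number 1.52 log units higher from compound 1 to compound 4 (beyond the scatter), the first sign that this aromatic carbon can drive potency strongly upward. With the heavy-atom count unchanged, the pair also shows that a hydrogen-bond acceptor in the group here is not needed for a high number. Nothing available explains the gain. The compounds shown leave open how a nitrile, a chlorine atom or a pentafluoroethyl group would compare with trifluoromethyl here. They also leave open whether the gain depends on the rest of the shared core.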